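Ethyl to pyridin-2-yl on the nitrogen: working notes

The source may report more compounds than this note shows. Statements on the series, on what has been measured and on what is new or still open speak of the compounds shown alone.

Measured so far in a functional assay on SK-MEL-28 cells (Homo sapiens) for cytotoxicity, read by MTT assay, with a stated time of 3 days (on this read-out lower numbers stand for stronger inhibition and higher numbers for weaker inhibition), for this series:
- compound 1 `N#Cc1c(NN)nc(SCc2nc3ccccc3[nH]2)nc1-c1ccccc1` gives 3 nM as measured
- compound 2 `CCNc1nc(SCc2nc3ccccc3[nH]2)nc(-c2ccccc2)c1C#N` gives 5.3 nM as measured

Compound 2 stands level with compound 1, the two values lying within the scatter of each other. Compound 3 `N#Cc1c(Nc2ccccn2)nc(SCc2nc3ccccc3[nH]2)nc1-c1ccccc1` differs from compound 2 by pyridin-2-yl in place of ethyl on a nitrogen on an aromatic ring with pyridin-2-yl in place of ethyl on a nitrogen on an aromatic ring. For the measured compounds named here, only the step of a 1.8-fold higher number from compound 1 to compound 2 (0.25 log units; within the scatter) at that place bears on this change, and no ring on this nitrogen has been measured. On these data alone, no step beyond the scatter is therefore expected in this assay and the direction stays open. The expected move is a 1.1-fold higher number from compound 2 to compound 3 (0.05 log units; within the scatter) by this estimate. For compound 3 the estimated value is 6 nM with a range of 1.5 nM to 24 nM for now.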

Compound 3, half-maximal inhibitory concentration: 8.9 nM
For compound 3 the middle estimate is 1.5-fold (0.17 log units) below the measured one; the range from low to high includes it.
By their numbers in this assay, from the lowest: compounds 1, 2 and 3 (each within the scatter of the next, the first and the last beyond it).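

In this assay, for the compounds shown here, pyridin-2-yl is the first ring on this nitrogen, and it stands level with ethyl, with a 1.7-fold higher number from compound 2 to compound 3 (0.23 log units; within the scatter). Set against amino, the same group gives the first step in the series beyond the scatter, though a modest one, with a 3.0-fold higher number from compound 1 to compound 3 (0.47 log units; beyond the scatter). No data at hand account for either step.

On these data alone, it remains open how phenyl, or a longer chain such as butyl, on this nitrogen would compare with pyridin-2-yl and ethyl.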